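This account rests on a few compounds, and the source may have more. Where it says the series, first, only, none or still open, it means among the compounds named here.

Measured so far in a toxicity assay on NIH3T3 cells (Mus musculus) for cytotoxicity, read by resazurin assay; on this read-out lower numbers stand for an effect already at smaller amounts and higher numbers for an effect only at larger amounts of compound:
- compound 1 `O=C(c1ccc(NCc2cncn2Cc2ccc(-c3ccccc3)cc2)cc1-c1ccccc1)N1CCCCC1`: > 1000 nM, a limit
- compound 2 `c1ccc(-c2ccc(Cn3cncc3CNc3ccc(-c4ccccc4)c(-c4ccccc4)c3)cc2)cc1`: > 10000 nM, a limit
- compound 3 `c1ccc(-c2ccc(Cn3cncc3CNc3ccc(-c4nc5ccccc5o4)c(-c4ccccc4)c3)cc2)cc1`: > 10000 nM, a limit

None of the three has a number behind it. Compound 3 stands at > 10000 nM, which is a limit and gives only a bound. Compound 2 shares that limit.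

The change to compound 4 `CN(C)C(=O)c1ccc(NCc2cncn2Cc2ccc(-c3ccccc3)cc2)cc1-c1ccccc1` puts dimethylcarbamoyl in place of 1,3-benzoxazol-2-yl on an aromatic carbon, ortho to a phenyl group: dimethylcarbamoyl in place of 1,3-benzoxazol-2-yl on an aromatic carbon.

All three measured steps fall at this same place: a step that the two limits leave unreadable from compound 1 to compound 2, a step that the two limits leave unreadable from compound 1 to compound 3 and a step that the two limits leave unreadable from compound 2 to compound 3. None of them has a readable size, so they give neither a magnitude nor a direction. The closest comparison is compound 1, whose (piperidin-1-yl)carbonyl stands where compound 4 carries dimethylcarbamoyl. The result of compound 1, > 1000 nM, is again a limit.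

No step beyond the scatter can therefore be foreseen in this assay, and a further limit is the likeliest report. The expected change is a number no higher from compound 3 to compound 4 (the limit leaves the size open). For compound 4 the estimate is 10000 nM, with an expected range from 2000 nM to 30000 nM.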

Compound 4, half-maximal effective concentration: > 1000 nM
Compound 4 was reported as a limit; the forecaster's own chance of this, stated with the estimate: 85%; the middle value does not contradict the limit.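

In this assay compound 4 is reported only as a limit, like compound 1, compound 2 and compound 3, and none of the steps linking compound 4 to those three can be read. The compounds shown leave open what amount of any of the four gives a half-maximal effect, and whether exchanging the groups changes it.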